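The compounds below may be only part of what the source reports. "The series", "measured", "known", "first", "only" and "open" are said of these compounds alone.

The series centres on a shared core carrying a three-carbon chain that joins two amine nitrogens, one of them bearing a benzyl group. Compound 2 `COc1cccc(CNCCCNc2ccnc3cc(Oc4ccc(F)cc4)ccc23)c1O` holds a 2-hydroxy-3-methoxyphenyl group on that chain carbon, and in an ADME assay on HepG2 cells (Homo sapiens) for cytotoxicity, read by luminescence, CellTiter-Glo and ATP content, with a stated time of 72 h (on this read-out higher numbers stand for an effect only at larger amounts of compound and lower numbers for an effect already at smaller amounts), compound 2 gives 11000 nM. Compound 1 `COc1ccc(F)cc1CNCCCNc1ccnc2cc(Oc3ccc(F)cc3)ccc12` differs from it in one place, (5-fluoro-2-methoxyphenyl in place of 2-hydroxy-3-methoxyphenyl on a saturated chain carbon bound to an amine nitrogen), and in this assay compound 1 gives 6600 nM. The step is a 1.7-fold lower number from compound 2 to compound 1 (0.22 log units; within the scatter), so the two values cannot be ordered.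

Compound 3 `COc1cccc(CNCCCNc2ccnc3cc(-c4cc(C(F)(F)F)cc(C(F)(F)F)c4)ccc23)c1O` keeps the 2-hydroxy-3-methoxyphenyl group of compound 2 but sits on a different core; the difference between the two cores is not broken down here. In this assay compound 3 gives 940 nM, the lowest of the three numbers, and its distance to compound 1 as well as to compound 2 lies beyond the scatter.

Compound 4 `COc1ccc(F)cc1CNCCCNc1ccnc2cc(-c3cc(C(F)(F)F)cc(C(F)(F)F)c3)ccc12` is still to be measured. It stands to compound 3 as compound 1 stands to compound 2: the change is 5-fluoro-2-methoxyphenyl in place of 2-hydroxy-3-methoxyphenyl on a saturated chain carbon bound to an amine nitrogen, the same change at the same place, now on the core of compound 3. The expected step reads a 1.6-fold lower number from compound 3 to compound 4 (0.19 log units; within the scatter), and it rests on the earlier step of a 1.7-fold lower number from compound 2 to compound 1 (0.22 log units; within the scatter), which stayed within the scatter. On that basis compound 4 is expected to give about 600 nM in this assay, with a range from 250 nM to 1500 nM.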

Compound 4, half-maximal effective concentration: 870 nM
Beside the measured number, compound 4's estimate is 1.5-fold (0.16 log units) below it; the range from low to high includes it.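

In this assay the exchange of 2-hydroxy-3-methoxyphenyl for 5-fluoro-2-methoxyphenyl, on a saturated chain carbon bound to an amine nitrogen, comes out as a 1.1-fold lower number from compound 3 to compound 4 (0.03 log units; within the scatter) and so leaves the two values unordered. Set beside the earlier step, the change reads alike on both cores: the same change on two cores in this assay, a 1.7-fold lower number (0.22 log units; within the scatter) from compound 2 to compound 1 and a 1.1-fold lower number (0.03 log units; within the scatter) from compound 3 to compound 4, 1.5-fold (0.19 log units) apart, within the scatter of two such steps. This shows that, on these two cores, the exchange leaves the number within the scatter, even though one group carries a hydrogen-bond donor and the other does not, but it does not show that the change has a fixed size that carries from core to core, since two steps this small could hide a modest difference and two cores are no basis for a rule about the series.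

The compounds shown leave open which part of the exchange matters, if any, since the hydroxyl, the fluorine and the shifted methoxy group all change together, and a plain 2-methoxybenzyl or 5-fluorobenzyl group would separate them. They also leave open whether the same quiet result holds with a longer chain, or with a nitrile or a carboxylic acid on the benzyl ring.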